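Swapping the sulfonyl aryl group in a benzoxazole sulfonamide

A few compounds are considered here, and "the series" means these few. Any claim that something is new, unique, unknown or untested is made for them only; others in the source may bear on it.

Compound 2 `O=S(=O)(Nc1ccc(-c2nc3ccccc3o2)cc1)c1cccs1` and compound 1 `Cc1ccc(S(=O)(=O)Nc2ccc(-c3nc4ccccc4o3)cc2)cc1` share one core and differ only on the sulfonyl sulfur. In an ADME assay on HEK293 cells (Homo sapiens) for cytotoxicity, read by resazurin assay, with a stated time of 48 h (on this read-out lower numbers stand for higher toxicity in this test and higher numbers for lower toxicity in this test), compound 1 gives 88000 nM. For compound 2 the test reports no number but only a limit, > 100000 nM. The step of an at least 1.1-fold higher number from compound 1 to compound 2 (0.05 log units; that floor lies within the scatter) therefore cannot be sized exactly, and the limit of > 100000 nM in this assay, at which 1 of the 2 values shown sits, shows where compound 2 sits.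

Compound 3 `COc1ccc(Cl)cc1S(=O)(=O)Nc1ccc(-c2nc3ccccc3o2)cc1` carries 5-chloro-2-methoxyphenyl in place of thiophen-2-yl on a sulfonyl sulfur. Among the measured compounds shown here, no measured step covers this exact exchange; the only related step, from thiophen-2-yl to 4-methylphenyl, stayed within the scatter and ended at a limit. An aryl group on the sulfonyl sulfur thus gave no clear shift, so in this assay the change from compound 2 to compound 3 is expected to be no larger than the scatter, as an at least 1.1-fold lower number from compound 2 to compound 3 (0.04 log units; that floor lies within the scatter). Compound 3 is estimated at 90000 nM, within 40000 nM to 200000 nM.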

Compound 3, half-maximal cytotoxic concentration: 75000 nM
Compound 3: the middle estimate sits 1.2-fold (0.08 log units) above what was measured; the range from low to high includes it.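

Among the compounds shown here, replacing 4-methylphenyl with 5-chloro-2-methoxyphenyl on a sulfonyl sulfur gives the first step at this place that can be sized exactly, a 1.2-fold lower number from compound 1 to compound 3 (0.07 log units; within the scatter) in this assay. These two differently substituted six-membered aromatic rings therefore cannot be told apart in this test, so the added chlorine and methoxy groups bring no change that stands clear of the scatter. The exchange of thiophen-2-yl reads an at least 1.3-fold lower number from compound 2 to compound 3 (0.12 log units; that floor lies within the scatter), and that is only a floor because compound 2 carries a limit and not a number: the limit of > 100000 nM in this assay, at which 1 of the 3 values shown sits.

Going by these compounds, all three groups on the sulfonyl sulfur are aromatic rings, so it stays open whether an amine, a carboxylic acid or a plain alkyl chain there would shift the number beyond the scatter. Also open, on these data alone, is how far the true value of compound 2 lies from the others.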